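A Methyl Added to the Sulfonyl Ring of Compound 1

The compounds below may be only part of what the source reports. "The series", "measured", "known", "first", "only" and "open" are said of these compounds alone.

Of the compounds shown here, two have been measured so far. Compound 1, `Cc1ncc([N+](=O)[O-])n1CC(=O)NS(=O)(=O)c1ccccc1`, was tested in a functional assay on B16-F10 cells (Mus musculus) for antiproliferative activity, read by MTT assay, with a stated time of 48 h (a higher number here means a weaker inhibitor, a lower number a stronger inhibitor), and gives 2.93 ug/mL. Within the data shown here, compound 2, `O=C(Cc1ccc(F)cc1)NS(=O)(=O)c1ccc(Cl)cc1`, is the only other measured compound, and in this assay compound 2 gives 6.36 ug/mL. Of these two numbers, compound 1 has the lower one, and the gap between compound 1 and compound 2 lies beyond the scatter of repeated measurements, so compound 1 stands as the stronger inhibitor of the pair. Compound 2 differs from compound 1 in several places at once, so its number says nothing on its own about any single change.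

The next compound, compound 3, `Cc1ccc(S(=O)(=O)NC(=O)Cn2c([N+](=O)[O-])cnc2C)cc1`, differs from compound 1 in one place only: methyl in place of hydrogen on an aromatic carbon. The change adds a single heavy atom. Among the measured compounds shown here, no measured pair shows what such a change does in this assay, so the expectation is a step from compound 1 to compound 3 that stays within the scatter, in either direction. Compound 3 is therefore expected to give 3 ug/mL in this assay, with a range from 1.5 ug/mL to 6 ug/mL. The step this estimate means, a 1.0-fold higher number from compound 1 to compound 3 (0.01 log units; within the scatter), is expected to be no larger than the usual scatter.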

Compound 3, half-maximal inhibitory concentration: 3.55 ug/mL
For compound 3 the middle estimate is 1.2-fold (0.07 log units) below the measured one; the measured number falls inside the stated range.
By their numbers in this assay, from the lowest: compounds 1, 3 and 2 (each within the scatter of the next, the first and the last beyond it).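

Among these compounds, the step from phenyl to 4-methylphenyl is the first single change that can be read in this assay and comes out as a 1.2-fold higher number from compound 1 to compound 3 (0.08 log units; within the scatter), within the scatter of repeated measurements. At this position, on an aromatic carbon para to a large group, the assay therefore shows no measurable difference when a methyl replaces hydrogen, so this spot can carry one added carbon without a clear loss or gain in antiproliferative activity. The data offer no measured explanation for this flat result.

From the compounds shown here alone, this single pair shows only what one small group does at one position, so it remains open whether an amine, a methoxy group, a carboxylic acid or a longer chain such as propyl would also leave the number unchanged there. Also open, going by these compounds, is whether a methyl on another carbon of the same ring, or the same phenyl to 4-methylphenyl change on a different core, would give a similarly small step.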